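Swapping a Formyl for a Cyano on a Nucleoside Side Chain

The source may hold more compounds than are shown below. What is called first, only, known or untested is meant among the compounds shown, and "the series" means these compounds.

Compound 2, with the structure `O=C/C=C/n1c(=O)ccn([C@H]2C[C@H](O)[C@@H](CO)O2)c1=O`, gives 800 nM in a functional assay on HeLa cells (Homo sapiens) for inhibition; a lower number here means a stronger inhibitor, a higher number a weaker inhibitor. Among the two measured compounds it carries the highest number, and its nearest neighbour is compound 1, `Cc1cn([C@H]2C[C@H](O)[C@@H](CO)O2)c(=O)n(/C=C/C=O)c1=O`, which gives 500 nM. Among the compounds with values here, the only measured step, a 1.6-fold higher number from compound 1 to compound 2 (0.20 log units; within the scatter), concerns a hydrogen in place of a methyl on an aromatic carbon and stays within the scatter.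

Compound 3, `N#C/C=C/n1c(=O)ccn([C@H]2C[C@H](O)[C@@H](CO)O2)c1=O`, differs from compound 2 in one place: cyano in place of formyl on a double-bonded chain carbon bound to a double-bonded chain carbon. Within the data shown here, no measured pair covers a change of this kind on the 2-formylethenyl chain, so the one measured step gives no guide here. The expectation must therefore stay wide. For compound 3 the step of a 1.9-fold higher number from compound 2 to compound 3 (0.27 log units; within the scatter) is estimated, leaning toward a higher number in this assay without a firm basis. The estimated value for compound 3 in this assay is 1500 nM, expected to fall between 400 nM and 6000 nM.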

Compound 3, half-maximal inhibitory concentration: 100000 nM
The estimate for compound 3 lay 67-fold (1.82 log units) below the measured number, and the stated range ends below it.
By their numbers in this assay, from the lowest: compounds 1 and 2 (each within the scatter of the next); then compound 3.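

On the 2-formylethenyl chain, the formyl group proves far more sensitive to change in this assay than the aromatic carbon that carries hydrogen or methyl: cyano in place of formyl gives a large loss of inhibition (a 130-fold higher number from compound 2 to compound 3 (2.10 log units; beyond the scatter)), while the earlier change stays within the scatter (a 1.6-fold higher number from compound 1 to compound 2 (0.20 log units; within the scatter)). Formyl and cyano each count 2 heavy atoms and 1 hydrogen-bond acceptor, so these counts do not separate the two groups. No measurement here accounts for the loss of inhibition.

Going by these compounds, it remains open whether this loss is specific to cyano or would also follow from another group in place of formyl, such as a carboxylic acid or an amide. Also open, on these data alone, is whether methyl on the aromatic carbon, as in compound 1, would alter the outcome with cyano on the chain.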